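Phenyl to 4-methylphenyl at the assay limit

This account rests on a few compounds, and the source may have more. Where it says the series, first, only, none or still open, it means among the compounds named here.

Measured in a functional assay on MGC-803 cells (Homo sapiens) for inhibition; a lower number here means a stronger inhibitor, a higher number a weaker inhibitor:
Compound 1 `O=C(CC(CC(=O)NC1Cc2ccccc2C1)c1ccc(Cl)cc1)NCCN1CCCCC1`: 89100 nM
Compound 2 `O=C(CC(CC(=O)NC1Cc2ccccc2C1)c1ccccc1)NCCN1CCCCC1`: > 100000 nM
Compound 3 `O=C(CC(CC(=O)NC1Cc2ccccc2C1)c1ccccc1)NCCN1CCCC1`: > 100000 nM

In this assay compound 2 gives > 100000 nM as a limit of the assay and not as a number. Compound 3 gives > 100000 nM as a limit too. The set thus sits largely at one mark, (the limit of > 100000 nM in this assay, at which 2 of the 3 values shown sit), and compound 1 alone has a number.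

Compound 4 `Cc1ccc(C(CC(=O)NCCN2CCCCC2)CC(=O)NC2Cc3ccccc3C2)cc1` is not yet measured. It differs from compound 2 by one change (methyl in place of hydrogen on an aromatic carbon): methyl in place of hydrogen on an aromatic carbon, para to a large group.

For the measured compounds named here, the one measured step on an aromatic carbon has hydrogen in place of chloro. It reads an at least 1.1-fold higher number from compound 1 to compound 2 (0.05 log units; that floor lies within the scatter) and so gives no change beyond the scatter. The other step, pyrrolidin-1-yl in place of piperidin-1-yl, reads a step that the two limits leave unreadable from compound 2 to compound 3 and lies away from the aromatic ring, so it does not bear on this change.

On the evidence of compound 1 and compound 2, no step beyond the scatter is expected in this assay, in either direction, and a report at the limit is the likeliest outcome. The expected step is small (a number no higher from compound 2 to compound 4 (the limit leaves the size open)). Compound 4 is estimated at 100000 nM (expected range 50000 nM to 200000 nM).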

Compound 4, half-maximal inhibitory concentration: > 100000 nM
Compound 4 ended at the assay's limit; the forecaster's own chance of this, stated with the estimate: 70%; the middle value lies on the limit itself.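

Methyl on this aromatic carbon, para to a large group, is a third group at a place that had so far carried only hydrogen and chloro, and it too leaves the compound without a number in this assay. Set against chloro at the same place, methyl gives an at least 1.1-fold higher number from compound 1 to compound 4 (0.05 log units; that floor lies within the scatter), so the measured floor does not separate the two groups, although the true gap could be larger. The step from hydrogen to methyl cannot be read, as both of its ends are limits, and the series now stands even more at a single mark: the limit of > 100000 nM in this assay, at which 3 of the 4 values shown sit.

The compounds shown leave open whether any group at this place can give a value clearly stronger than that of compound 1, as an amine, a methoxy group or a carboxylic acid on the same carbon would show. They also leave open how far compound 2 and compound 4 lie from the limit, so any real effect of methyl in place of hydrogen stays hidden in this assay.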